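Methoxycarbonyl to benzyloxycarbonyl: notes on compound 3

The source may hold more compounds than are shown below. What is called first, only, known or untested is meant among the compounds shown, and "the series" means these compounds.

Measured in a functional assay on BIU87 cells (Homo sapiens) for cytotoxicity, read by MTT assay (on this read-out lower numbers stand for stronger inhibition and higher numbers for weaker inhibition), so far:
- compound 1 `C=C1C[C@]23C[C@@]1(O)CC[C@H]2[C@@]12C=C[C@H](O)[C@](C)(C(=O)O1)[C@H]2[C@@H]3C(=O)OCc1ccccc1` gives > 100 ug/mL as a limit
- compound 2 `C=C1[C@H](O)[C@]23C[C@@]1(O)CC[C@H]2[C@@]12C=C[C@H](O)[C@](C)(C(=O)O1)[C@H]2[C@@H]3C(=O)OC` gives > 100 ug/mL as a limit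

Compound 2 gives > 100 ug/mL here, and this is a limit and not a number. Among the compounds with values here, the measured series shows the limit of > 100 ug/mL in this assay, at which 2 of the 2 values shown sit, and so yields no step between compounds. Compound 3 `C=C1[C@H](O)[C@]23C[C@@]1(O)CC[C@H]2[C@@]12C=C[C@H](O)[C@](C)(C(=O)O1)[C@H]2[C@@H]3C(=O)OCc1ccccc1` differs from compound 2 by phenyl in place of hydrogen on a saturated chain carbon bound to an oxygen next to a carbonyl group with phenyl in place of hydrogen on a saturated chain carbon bound to an oxygen next to a carbonyl group, which reads as methoxycarbonyl to benzyloxycarbonyl. With compound 2 at the limit of > 100 ug/mL no step beyond the scatter is expected in this assay in either direction. The expected step of a number no higher from compound 2 to compound 3 (the limit leaves the size open) is small. A report as a limit again is the likeliest outcome. For compound 3 the estimate is 100 ug/mL with an expected range from 50 ug/mL to 200 ug/mL on this reasoning.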

Compound 3, half-maximal inhibitory concentration: > 100 ug/mL
Compound 3: no number, only a limit; the forecaster's own chance of this, stated with the estimate: 75%; the middle value lies on the limit itself.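

In this assay compound 3 gives > 100 ug/mL, which is a limit and not a number. No step can be read between compound 3 and either compound 1 or compound 2, as all three share one limit: the limit of > 100 ug/mL in this assay, at which 3 of the 3 values shown sit. The compounds shown leave open whether either change, methoxycarbonyl to benzyloxycarbonyl or hydroxy in place of hydrogen on a saturated ring carbon, affects the read-out.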